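The compounds below may be only part of what the source reports. "The series", "measured", "known", "first", "only" and "open" are said of these compounds alone.

In an ADME assay on MT4 cells (Homo sapiens) for cytotoxicity, read by MTT assay (a higher number here means that more compound is tolerated, a lower number that less compound is tolerated), compound 1 `Cc1cc(C)cc(S(=O)(=O)c2c(C(=O)NCC(=O)NC(C)c3ccccc3)[nH]c3ccc(Cl)cc23)c1` gives 29400 nM as its half-maximal cytotoxic concentration. Compound 3 `Cc1cc(C)cc(S(=O)(=O)c2c(C(=O)NCC(=O)NCCn3c(C)cnc3[N+](=O)[O-])[nH]c3ccc(Cl)cc23)c1` gives 24500 nM in the same test, so the two sit level, with a 1.2-fold lower number from compound 1 to compound 3 (0.08 log units; within the scatter). Compound 2 `Cc1cc(C)cc(S(=O)(=O)c2c(C(=O)NC(c3ccc(Cl)cc3)C3CC3)[nH]c3ccc(Cl)cc23)c1` reports only a limit, > 47300 nM. Its step is an at least 1.6-fold higher number from compound 1 to compound 2 (0.20 log units; that floor lies within the scatter). Compound 4 `Cc1cc(C)cc(S(=O)(=O)c2c(C(=O)NCC(=O)NCc3ccncn3)[nH]c3ccc(Cl)cc23)c1` differs from compound 3 by one change: a group of 6 heavy atoms (4 carbon, 2 nitrogen; one six-membered aromatic ring with 2 hetero atoms) in place of a group of 10 heavy atoms (5 carbon, 3 nitrogen, 2 oxygen; one five-membered aromatic ring with 2 hetero atoms), on a saturated chain carbon bound to an amide-type nitrogen. The closest guide is the swap from compound 1 to compound 3, another group exchange on this side chain, which stayed within the scatter. No step beyond the scatter is therefore expected in this assay. The estimated step is a 1.2-fold higher number from compound 3 to compound 4 (0.09 log units; within the scatter). For compound 4 the expected value is 30000 nM, with an estimated range from 13000 nM to 70000 nM.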

Compound 4, half-maximal cytotoxic concentration: > 48800 nM
Compound 4 was reported as a limit; the forecaster's own chance of this, stated with the estimate: 35%; middle value at least 1.6-fold (0.21 log units) from the limit.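

In this assay, pyrimidin-4-yl on the saturated chain carbon gives an at least 1.9-fold higher number from compound 3 to compound 4 (0.29 log units; that floor lies within the scatter), and (pyrimidin-4-yl)methyl in place of 1-phenylethyl gives an at least 1.6-fold higher number from compound 1 to compound 4 (0.22 log units; that floor lies within the scatter). Compound 4 reports a limit, not a number, so both steps are floors, and neither floor clears the scatter. Going by these compounds alone, still, this side chain now also reaches a limit, which among the earlier compounds only compound 2, with a different group on the amide-type nitrogen, had done. Going by these compounds, the step between compound 2 and compound 4 cannot be read, and the true sizes of the other two steps stay unknown. On these data alone, how an amine or a carboxylic acid in this place would read also stays open.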